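A few compounds are considered here, and "the series" means these few. Any claim that something is new, unique, unknown or untested is made for them only; others in the source may bear on it.

Measured so far:
- compound 1 `CN(C)CCCCNc1nc2cc([N+](=O)[O-])ccc2nc1NCc1ccc(C(F)(F)F)cc1`: 9.73 ug/mL
- compound 2 `O=[N+]([O-])c1ccc2nc(NCc3ccc(C(F)(F)F)cc3)c(N3CCNCC3)nc2c1`: 9.61 ug/mL
- compound 3 `CN(C)CCCNc1nc2cc([N+](=O)[O-])ccc2nc1NCc1ccc(F)cc1`: 4.28 ug/mL

In an ADME assay on HEK293 cells (Homo sapiens) for cytotoxicity, read by MTT assay, with a stated time of 24 h (a higher number here means a weaker inhibitor, a lower number a stronger inhibitor), compound 3 gives 4.28 ug/mL, the lowest of the three numbers. Compound 1 and compound 2 both lie higher, beyond the scatter, but each differs from compound 3 in more than one place, so that gap cannot be assigned to a single change.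

Compound 4 `CN(C)CCCNc1nc2cc([N+](=O)[O-])ccc2nc1NCc1cccc(Br)c1` keeps everything in compound 3 except the benzyl group, where 3-bromophenyl stands in place of 4-fluorophenyl: 3-bromophenyl in place of 4-fluorophenyl on a saturated chain carbon bound to a nitrogen on an aromatic ring.

Among the compounds with values here, the only measured single-place step, a 1.0-fold lower number from compound 1 to compound 2 (0.01 log units; within the scatter), concerns another part of the molecule and stayed within the scatter. Within the data shown here, it therefore gives no size for this change, and no measured step touches this group. As far as these compounds go, with nothing to suggest a shift, no change beyond the scatter is expected in this assay, and the direction remains open. The expected step is a 1.2-fold higher number from compound 3 to compound 4 (0.07 log units; within the scatter). The estimate for compound 4 is 5 ug/mL, with an expected range from 2.5 ug/mL to 10 ug/mL.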

Compound 4, half-maximal inhibitory concentration: 3.66 ug/mL
For compound 4 the middle estimate is 1.4-fold (0.14 log units) above the measured one; measured number inside the range.
By their numbers in this assay, from the lowest: compounds 4 and 3 (each within the scatter of the next); then compounds 2 and 1 (each within the scatter of the next).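

In this assay, the benzyl group now has its first measured single-place step: a 1.2-fold lower number from compound 3 to compound 4 (0.07 log units; within the scatter) stays within the scatter. The exchange of 4-fluorophenyl for 3-bromophenyl alters both the halogen and where it is named on the ring, yet this pair shows no change that can be read beyond the scatter, on the side chain shared by compound 3 and compound 4. No measurement at hand explains this outcome.

The two parts of the exchange remain fused, as neither 3-fluorophenyl nor 4-bromophenyl appears here to separate the halogen from its place. As far as these compounds go, it also remains open whether a plain phenyl ring, or a methoxy group or nitrile on that ring, would keep the number within the same scatter.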